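A few compounds are considered here, and "the series" means these few. Any claim that something is new, unique, unknown or untested is made for them only; others in the source may bear on it.

In a functional assay on C6 cells (Rattus norvegicus) for cytotoxicity, read by MTT assay, with a stated time of 24 h (on this read-out higher numbers stand for weaker inhibition and lower numbers for stronger inhibition), compound 2 `Cc1cc(-c2nc3ccccc3o2)ccc1NC(=O)CN1CCN(CCCN(C)C)CC1` gives 38700 nM. For the measured compounds named here, compound 1 `Cc1cc(-c2nc3cc(Cl)ccc3o2)ccc1NC(=O)CN1CCN(CCCN(C)C)CC1` carries the change chloro in place of hydrogen on an aromatic carbon and gives 14200 nM; the step of a 2.7-fold lower number from compound 2 to compound 1 (0.44 log units; beyond the scatter) is the one direct comparison in hand. Compound 3 `Cc1cc(-c2nc3ccccc3o2)ccc1NC(=O)CCl` gives 27200 nM; the difference between the core of compound 3 and that of compound 2 is not broken down here, and the numbers for compound 3 and compound 2 sit within the scatter of each other. Compound 4 `Cc1cc(-c2nc3cc(Cl)ccc3o2)ccc1NC(=O)CCl` is not yet measured; it differs from compound 3 by chloro in place of hydrogen on an aromatic carbon, the same change as between compound 2 and compound 1, at the same place. Because a 2.7-fold lower number from compound 2 to compound 1 (0.44 log units; beyond the scatter) went beyond the scatter, a step of similar size is expected, a 2.5-fold lower number from compound 3 to compound 4 (0.39 log units; beyond the scatter), though this rests on a single precedent. Compound 4 is therefore estimated at about 11000 nM, expected to fall between 4500 nM and 28000 nM.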

Compound 4, half-maximal inhibitory concentration: > 100000 nM
Compound 4 ended at the assay's limit; the forecaster's own chance of this, stated with the estimate: 5%; at least 9.0-fold (0.95 log units) between middle value and limit.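

In this assay compound 4 gives > 100000 nM, which is a limit of the assay and not a number. Chloro in place of hydrogen on an aromatic carbon now gives an at least 3.6-fold higher number from compound 3 to compound 4 (0.56 log units; beyond the scatter), so the change does not carry over from the core of compound 2 to the core of compound 3, and its direction reverses: the same change on two cores in this assay, a 2.7-fold lower number (0.44 log units; beyond the scatter) from compound 2 to compound 1 and an at least 3.6-fold higher number (0.56 log units; beyond the scatter) from compound 3 to compound 4, at least 10-fold (1.00 log units) apart, beyond the scatter of two such steps This rests on a single pair per core and gives no reason for the reversal, and the step from compound 3 is only a bound: the limit of > 100000 nM in this assay, at which 1 of the 4 values shown sits.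

Open, from the compounds shown here alone, is whether fluoro or methoxy at the same place would follow the direction of compound 1 or that of compound 4. Also open, going by these compounds, is which direction the chloro change takes with a simple amine in place of the side chain of compound 1.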